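The compounds below may be only part of what the source reports. "The series", "measured", "known", "first", "only" and "open" are said of these compounds alone.

Three compounds share one core and differ only in the group attached to the carbonyl carbon next to the amide-type nitrogen. Compound 1 `Cc1ccc(C(=O)N[C@@H](C(=O)N2CCC(c3ccc(Cl)cc3)CC2)C(C)C)cc1` carries a 4-methylphenyl there and gives 25 nM in an assay on THP-1 cells for displacement of a labelled ligand from C-C chemokine receptor type 1 (Homo sapiens); a higher number here means a weaker inhibitor, a lower number a stronger inhibitor. Compound 2 `CC(C)[C@@H](NC(=O)CCc1ccc(F)cc1)C(=O)N1CCC(c2ccc(Cl)cc2)CC1` carries a 2-(4-fluorophenyl)ethyl and gives 70 nM in this assay. Compound 3 `CC(C)[C@@H](NC(=O)c1ccc(F)cc1)C(=O)N1CCC(c2ccc(Cl)cc2)CC1` carries a 4-fluorophenyl and gives 118 nM in this assay, the highest of the three numbers: it lies a 4.7-fold higher number from compound 1 to compound 3 (0.67 log units; beyond the scatter), whereas the step of a 1.7-fold higher number from compound 2 to compound 3 (0.23 log units; within the scatter) is within the scatter.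

Compound 4 `CC(C)[C@@H](NC(=O)NCc1ccccc1)C(=O)N1CCC(c2ccc(Cl)cc2)CC1` differs from compound 3 by benzylamino in place of 4-fluorophenyl on a carbonyl carbon. Going by the values given here, no measured pair shows this exact change. The closest guides are the two changes made at the same carbonyl carbon, a 2.8-fold higher number from compound 1 to compound 2 (0.45 log units; beyond the scatter) and a 1.7-fold higher number from compound 2 to compound 3 (0.23 log units; within the scatter), which were modest or within the scatter even when the group changed shape. On that basis only a small step is expected in this assay, a 1.1-fold lower number from compound 3 to compound 4 (0.03 log units; within the scatter), with no clear direction. Compound 4 is therefore estimated at 110 nM in this assay, with a range from 40 nM to 320 nM.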

Compound 4, half-maximal inhibitory concentration: 180 nM
Compound 4: middle estimate off by 1.6-fold (0.21 log units), on the low side; the measured number falls inside the stated range.
By their numbers in this assay, from the lowest: compound 1; then compounds 2, 3 and 4 (each within the scatter of the next, the first and the last beyond it).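

The benzylamino group brings in a nitrogen and a hydrogen-bond donor, neither of which appears in the three earlier groups on this carbonyl carbon, yet in this assay the exchange for 4-fluorophenyl is only a 1.5-fold higher number from compound 3 to compound 4 (0.18 log units; within the scatter). The gaps to the other two groups are wider, at a 2.6-fold higher number from compound 2 to compound 4 (0.41 log units; beyond the scatter) and a 7.2-fold higher number from compound 1 to compound 4 (0.86 log units; beyond the scatter), so the added nitrogen gives no gain here and the 4-methylphenyl group keeps the lowest number of the four. Nothing available explains why the numbers fall in this order.

The benzylamino group also lacks the fluoro substituent on its ring, so the shown compounds cannot separate the effect of the nitrogen from the effect of that fluoro, a question that 4-fluorobenzylamino or 4-methylbenzylamino on the same carbonyl carbon would address. Every group shown also ends in an aromatic ring, which leaves open how this position would respond to a group with no ring at all, such as a plain butyl chain, a primary amine or a carboxylic acid.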